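The source may hold more compounds than are shown below. What is called first, only, known or untested is meant among the compounds shown, and "the series" means these compounds.

Compound 3 `Cc1nc(C(F)(F)F)ccc1C(=O)Nc1ccc(Cl)c(-c2ccn(C)n2)c1` gives the highest number of the three in an assay on C3H 10T1/2 cells for inhibition of Sonic hedgehog protein (Mus musculus), read by a luciferase reporter (a higher number here means a weaker inhibitor, a lower number a stronger inhibitor), at 550 nM for compound 3. Its nearest neighbour is compound 2 `Cc1nc(C(F)(F)F)ccc1C(=O)Nc1ccc(Cl)c(C(=O)Nc2ccccc2)c1`, which in this assay gives 140 nM; the step of a 3.9-fold higher number from compound 2 to compound 3 (0.59 log units; beyond the scatter) lies beyond the scatter. Furthest away is compound 1 `Cc1nc(C(F)(F)F)ccc1C(=O)Nc1ccc(Cl)c(-c2nc3ccccc3n2C)c1`, which gives 9 nM in this assay, and the step of a 61-fold higher number from compound 1 to compound 3 (1.79 log units; beyond the scatter) is large.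

Compound 4 `Cc1nc(C(F)(F)F)ccc1C(=O)Nc1ccc(Cl)c(-c2cnccn2)c1` differs from compound 3 by a single change: pyrazin-2-yl in place of 1-methyl-1H-pyrazol-3-yl on an aromatic carbon. Both measured steps that touch this position, a 61-fold higher number from compound 1 to compound 3 (1.79 log units; beyond the scatter) and a 3.9-fold higher number from compound 2 to compound 3 (0.59 log units; beyond the scatter), show that what sits on this aromatic carbon moves the number strongly, and in every case the 1-methyl-1H-pyrazol-3-yl has given the highest number. Going by the values given here, a pyrazin-2-yl at the same place has no measured precedent, so the direction is uncertain; a small improvement is expected because the change a 3.9-fold higher number from compound 2 to compound 3 (0.59 log units; beyond the scatter) shows a different neighbour here already lowers the number. The step is therefore estimated as a 1.8-fold lower number from compound 3 to compound 4 (0.26 log units; within the scatter). In this assay compound 4 is expected to give 300 nM, within a range from 80 nM to 1200 nM.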

Compound 4, half-maximal inhibitory concentration: 1700 nM
Beside the measured number, compound 4's estimate is 5.7-fold (0.75 log units) below it; the whole stated range lies below it.
By their numbers in this assay, from the lowest: compound 1; then compound 2; then compound 3; then compound 4.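

In this assay the change to pyrazin-2-yl gives a 3.1-fold higher number from compound 3 to compound 4 (0.49 log units; beyond the scatter) even though the counts of heavy atoms, carbon, nitrogen, donors and acceptors stay the same, so this position separates two groups that differ in those counted features only by a five-membered versus a six-membered aromatic ring. The span at this aromatic carbon also grows, with a 12-fold higher number from compound 2 to compound 4 (1.08 log units; beyond the scatter) and a 190-fold higher number from compound 1 to compound 4 (2.28 log units; beyond the scatter) and compound 4 now the weakest inhibitor of the four. Nothing available explains why the pyrazin-2-yl falls behind the 1-methyl-1H-pyrazol-3-yl.

Going by these compounds, it remains open whether a pyridin-2-yl or a plain phenyl on this carbon would lie nearer compound 1 or compound 4. On these data alone, the effect of an amine or a carboxylic acid at this place also remains open.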